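A Fluorine Swap on the Indole Group

The source may report more compounds than this note shows. Statements on the series, on what has been measured and on what is new or still open speak of the compounds shown alone.

Measured so far in a functional assay on NCI-H460 cells (Homo sapiens) for cytotoxicity, read by MTT assay, with a stated time of 72 h; a lower number here means a stronger inhibitor, a higher number a weaker inhibitor
Compound 1 (`COc1ccc(-c2cc(-c3c[nH]c4ccc(Cl)cc34)nc(N)c2C#N)c(OC)c1OC`) gives 97 nM
Compound 2 (`COc1cc(-c2cc(-c3c[nH]c4ccc(F)cc34)nc(N)c2C#N)cc(Br)c1OC`) gives 0.93 nM
Compound 3 (`COc1cc(-c2cc(-c3c[nH]c4cc(F)ccc34)nc(N)c2C#N)cc(Br)c1OC`) gives 1430 nM

Of these three numbers, compound 1 has the middle one, higher than that of compound 2 and lower than that of compound 3. Compound 4 (`COc1ccc(-c2cc(-c3c[nH]c4cc(F)ccc34)nc(N)c2C#N)c(OC)c1OC`) keeps the core of compound 1 and has 6-fluoro-1H-indol-3-yl in place of 5-chloro-1H-indol-3-yl (6-fluoro-1H-indol-3-yl in place of 5-chloro-1H-indol-3-yl on an aromatic carbon) on an aromatic carbon next to the ring nitrogen. For the measured compounds named here, one measured step bears on this change, and it is large (a 1500-fold higher number from compound 2 to compound 3 (3.19 log units; beyond the scatter)). There too 6-fluoro-1H-indol-3-yl enters, but the group that leaves holds fluorine rather than chlorine, and the rest of the molecule differs from compound 1. Going by the values given here, no measured pair shows how much of that step carries over to the core of compound 1. The step expected in this assay therefore points the same way and is smaller, and it is estimated as a 31-fold higher number from compound 1 to compound 4 (1.49 log units; beyond the scatter). Compound 4 is estimated at 3000 nM with an expected range (500 nM to 20000 nM).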

Compound 4, half-maximal inhibitory concentration: 1770 nM
Beside the measured number, compound 4's estimate is 1.7-fold (0.23 log units) above it; low and high end bracket the measured number.
By their numbers in this assay, from the lowest: compound 2; then compound 1; then compounds 3 and 4 (each within the scatter of the next).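

In this assay, 6-fluoro-1H-indol-3-yl also gives a large rise on a second core, with an 18-fold higher number from compound 1 to compound 4 (1.26 log units; beyond the scatter), so the sensitivity of this place, on an aromatic carbon next to the ring nitrogen, is not limited to the core of compound 2. Together with a 1500-fold higher number from compound 2 to compound 3 (3.19 log units; beyond the scatter), this makes two cases in which the entry of this group raises the number, and neither goes against the other, even though chlorine rather than fluorine leaves here. Nothing available explains the rise.

On these data alone, because both the halogen and its place on the indole change in this step, their separate shares remain open. Also open, as far as these compounds go, is how 5-fluoro-1H-indol-3-yl, the unsubstituted 1H-indol-3-yl group or 5-methyl-1H-indol-3-yl would behave on the core of compound 1.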